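A few compounds are considered here, and "the series" means these few. Any claim that something is new, unique, unknown or untested is made for them only; others in the source may bear on it.

Measured compounds:

Compound 1 `CNc1nc(NCCCN(C)C)c2oc(-c3ccccc3)cc2n1`: 214 ug/mL
Compound 2 `CNc1nc(NCCCN(C)C)c2sc(-c3ccc(N)cc3)cc2n1`: > 100 ug/mL
Compound 3 `CNc1nc(NCCCN(C)C)c2cc(-c3ccccc3)sc2n1`: 216 ug/mL

These three compounds share a core that carries a methylamino group and a dimethylaminopropylamino chain, and differ in the aromatic ring fused to that core and in the phenyl group attached to it. In a physicochemical assay for solubility, at pH 2 (a lower number here means a less soluble compound, a higher number a more soluble compound), compound 1 gives 214 ug/mL. In this assay, going by the values given here, compound 3 gives 216 ug/mL, a value within the usual scatter of the one for compound 1. For compound 2 the read-out is a limit of the assay rather than a number: > 100 ug/mL. This is where compound 2 stands, as described by the limit of > 100 ug/mL in this assay, at which 1 of the 3 values shown sits, so its true solubility is not pinned down.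

Compound 4 `CNc1nc(NCCCN(C)C)c2sc(-c3ccc(NS(C)(=O)=O)cc3)cc2n1` has not yet been measured in this assay. It differs from compound 2 by one change, (methylsulfonyl in place of hydrogen on a nitrogen on an aromatic ring). Among the compounds with values here, no measured pair shows the effect of this change, so the expectation rests only on the values above. Compound 4 is estimated to be somewhat less soluble than the numbers seen for compound 1 and compound 3, with a step that the limit leaves unreadable from compound 2 to compound 4 that is expected to be modest, and an expected value of 110 ug/mL, within 35 ug/mL to 320 ug/mL.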

Compound 4, solubility: > 100 ug/mL
Compound 4 ended at the assay's limit; the forecaster's own chance of this, stated with the estimate: 30%; the middle value does not contradict the limit.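

In this assay, compound 2 and compound 4 both end at a limit of the assay rather than at a number, so no step between them can be read: the limit of > 100 ug/mL in this assay, at which 2 of the 4 values shown sit.

The compounds shown leave open how the true solubility of compound 4 compares with that of compound 2, and so what placing methylsulfonyl in place of hydrogen on this nitrogen changes.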